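A few compounds are considered here, and "the series" means these few. Any claim that something is new, unique, unknown or untested is made for them only; others in the source may bear on it.

The measured compounds:

Compound 1, `COc1cc(Nc2nc3ccccc3nc2S(=O)(=O)c2ccccc2)cc(OC)c1OC`. In a functional assay on HCT-116 cells (Homo sapiens) for cytotoxicity, read by MTT assay, with a stated time of 72 h (a higher number here means a weaker inhibitor, a lower number a stronger inhibitor), compound 1 gives > 50000 nM, which is a limit of the assay and not a number.

Compound 2, `COc1ccc(S(=O)(=O)c2nc3ccccc3nc2Nc2cc(OC)c(OC)c(OC)c2)cc1`. In this assay compound 2 gives > 50000 nM, again a limit rather than a number.

Compound 3, `O=S(=O)(c1ccc(Br)cc1)c1nc2ccccc2nc1Nc1ccccc1`. In this assay compound 3 gives 1110 nM.

Compound 2 differs from compound 1 by one change, (methoxy in place of hydrogen on an aromatic carbon). The step that the two limits leave unreadable from compound 1 to compound 2 cannot be read, because of the limit of > 50000 nM in this assay, at which 2 of the 3 values shown sit, so these two compounds say nothing about how large or in which direction that change moves the read-out.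

Compound 4, `COc1ccc(Nc2nc3ccccc3nc2S(=O)(=O)c2ccc(Br)cc2)cc1`, has not yet been measured. It differs from compound 3 by methoxy in place of hydrogen on an aromatic carbon. Among the measured compounds shown here, this is the same kind of change as the one from compound 1 to compound 2, and the place is described in the same words, on an aromatic carbon of a six-membered aromatic ring of carbon only, para to a large group; seen one bond further out, however, the earlier change reads phenylsulfonyl to (4-methoxyphenyl)sulfonyl, while here it reads anilino to (4-methoxyphenyl)amino. The difference between the core of compound 1 and the core of compound 3 is not broken down here.

With the earlier step unreadable, the expectation for compound 4 rests only on compound 3 and its value 1110 nM, and the step from compound 3 to compound 4 is expected to stay within the usual scatter, a 1.4-fold higher number from compound 3 to compound 4 (0.13 log units; within the scatter). Compound 4 is therefore estimated to give about 1500 nM in this assay, most likely between 400 nM and 6000 nM.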

Compound 4, half-maximal inhibitory concentration: 3400 nM
For compound 4 the middle estimate is 2.3-fold (0.36 log units) below the measured one, within the range that was stated.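

Replacing anilino with (4-methoxyphenyl)amino gives a 3.1-fold higher number from compound 3 to compound 4 (0.49 log units; beyond the scatter) in this assay, so on this core the methoxy group goes with a modest loss of strength. Among the compounds shown here, this does not show whether the effect carries from one core to another, because the only other example of this kind of change, from compound 1 to compound 2, cannot be read: the limit of > 50000 nM in this assay, at which 2 of the 4 values shown sit. Even a readable pair would not be a clean test, as that earlier change reads phenylsulfonyl to (4-methoxyphenyl)sulfonyl and therefore falls on a different part of the molecule as well as on a different core, leaving a single readable step on a single core.

The compounds shown leave open whether this loss is particular to methoxy or would also appear with another group at the same place, such as an amine, a carboxylic acid or a longer chain like ethoxy. They also leave open which of the differences between the core of compound 1 and the core of compound 3 matters in this assay, as those two compounds differ in more than one place.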